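Replacing a phenyl with a pyrrolidinyloxy group

The compounds below may be only part of what the source reports. "The series", "measured", "known", "first", "only" and "open" are said of these compounds alone.

The series shares one core, shown in compound 1 `Nc1cc(Cc2ccn(Cc3cccc(-c4ccccc4)c3)n2)c2nn[nH]c2n1`. In an assay on isolated protein for inhibition of Myeloperoxidase (Homo sapiens), with a stated time of 10 min (a higher number here means a weaker inhibitor, a lower number a stronger inhibitor), compound 1 gives 55 nM, the highest of the three numbers recorded. Compound 2 `Nc1cc(Cc2ccn(-c3ccccn3)n2)c2nn[nH]c2n1` gives 54 nM in this assay, a value within the scatter of compound 1. Compound 3 `Nc1cc(C2CCNCCc3cccc(c3)-c3cccc(c3)Cn3cc2cn3)c2nn[nH]c2n1` gives 21 nM, a lower number that lies beyond the scatter from compound 1. Compound 4 `Nc1cc(Cc2ccn(Cc3cccc(O[C@H]4CCNC4)c3)n2)c2nn[nH]c2n1` is not yet measured; it differs from compound 1 by (pyrrolidin-3-yl)oxy in place of phenyl on an aromatic carbon. Among the compounds with values here, no measured pair isolates this change, so a step of no more than the scatter, in either direction, is expected in this assay. Compound 4 is therefore estimated at 45 nM, in a range from 15 nM to 140 nM, which corresponds to an expected step of a 1.2-fold lower number from compound 1 to compound 4 (0.09 log units; within the scatter).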

Compound 4, half-maximal inhibitory concentration: 46 nM
Compound 4: middle estimate off by 1.0-fold (0.01 log units), on the low side; measured number inside the range.
By their numbers in this assay, from the lowest: compound 3; then compounds 4, 2 and 1 (each within the scatter of the next).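

In this assay, within the data shown here, a 1.2-fold lower number from compound 1 to compound 4 (0.08 log units; within the scatter) gives the first measured pair that isolates this position. On an aromatic carbon meta to a large group, phenyl and (pyrrolidin-3-yl)oxy give numbers within the scatter, although the entering group brings a non-aromatic ring, hydrogen-bond donor and acceptors, and a defined stereocentre. No supporting evidence bears on why this is so. Still open, as far as these compounds go, is how the opposite stereoisomer, an N-methylpyrrolidinyloxy group, a piperidinyloxy group or an open-chain aminoethoxy group would read at this place.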